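A dimethylamino swap on an unmeasured amide

The compounds below may be only part of what the source reports. "The series", "measured", "known", "first", "only" and "open" are said of these compounds alone.

Measured in a functional assay on A2780 cells (Homo sapiens) for inhibition; a higher number here means a weaker inhibitor, a lower number a stronger inhibitor

compound 1 `CCNC(=O)c1noc(-c2cc(C(C)C)c(O)cc2O)c1-c1cc(COCC(N)=O)no1` gives "not determined" (no result reported)
compound 2 `CCNCc1cc(-c2c(C(=O)NCC)noc2-c2cc(C(C)C)c(O)cc2O)on1` gives 45 nM
compound 3 `CCNC(=O)c1noc(-c2cc(C(C)C)c(O)cc2O)c1-c1cc(CNC(=O)CC)no1` gives "not determined" (no result reported)

In this assay compound 3 gives "not determined" (no result reported) and so has no single number, and compound 1 likewise has none. Compound 4 `CCNC(=O)c1noc(-c2cc(C(C)C)c(O)cc2O)c1-c1cc(CN(C)C)no1` has no result yet. The structural change dimethylamino in place of propanoylamino on a saturated chain carbon bound to an aromatic carbon puts dimethylamino in place of propanoylamino on a saturated chain carbon bound to an aromatic carbon. For the measured compounds named here, no measured step exists to size this change. Going by the values given here, the only number available is that of compound 2 (45 nM), and no difference from it beyond the usual scatter is expected, in either direction. Compound 4 is expected at 40 nM (estimated range 12 nM to 130 nM) when it is measured.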

Compound 4, half-maximal inhibitory concentration: 31 nM
The estimate for compound 4 lay 1.3-fold (0.11 log units) above the measured number, within the range that was stated.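

In this assay, dimethylamino in place of ethylamino on a saturated chain carbon bound to an aromatic carbon gives a 1.5-fold lower number from compound 2 to compound 4 (0.16 log units; within the scatter), so a second alkyl-substituted amine at this place reads the same as the first. Compound 3 gives "not determined" (no result reported), so the change from propanoylamino cannot be sized. No data on any property of these groups accompany the result. As far as these compounds go, whether a primary amine, a morpholine or a carboxylic acid on the same saturated chain carbon would read alike stays open.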